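Cytotoxicity on Vero cells: a methoxy-for-propoxy swap on a chalcone

The compounds below may be only part of what the source reports. "The series", "measured", "known", "first", "only" and "open" are said of these compounds alone.

Measured compounds:
compound 1 `CCCOc1ccc(C(=O)/C=C/c2ccc(C(=O)Nc3cccc(-c4cc(C(=O)OC)no4)c3)cc2)cc1` — > 40 ug/mL
compound 2 `COC(=O)c1cc(-c2ccc(NC(=O)c3ccc(/C=C/C(=O)c4ccc(Cl)cc4)cc3)cc2)on1` — > 80 ug/mL

Compound 1 is known only through a limit. In an ADME assay on Vero cells (Chlorocebus sabaeus) for cytotoxicity, read by MTT assay, with a stated time of 72 h (a lower number here means that less compound is tolerated, a higher number that more compound is tolerated), compound 1 gives > 40 ug/mL, which is a limit of the assay and not a number. For compound 2 this assay likewise returns > 80 ug/mL, again a limit rather than a number. So neither value fixes a point on the scale; both sit at their limits the limit of > 40 ug/mL in this assay, at which 1 of the 2 values shown sits (the limit of > 80 ug/mL in this assay, at which 1 of the 2 values shown sits), and no step between measured compounds can be counted.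

Compound 3 `COC(=O)c1cc(-c2cccc(NC(=O)c3ccc(/C=C/C(=O)c4ccc(OC)c(OC)c4)cc3)c2)on1` keeps the core of compound 1 and differs in one place: 3,4-dimethoxyphenyl in place of 4-propoxyphenyl on a carbonyl carbon. The change is 3,4-dimethoxyphenyl in place of 4-propoxyphenyl on a carbonyl carbon whose other neighbour is a double-bonded chain carbon.

With only limits to go on, the step from compound 1 to compound 3 in this assay is expected to be a step that the limit leaves unreadable from compound 1 to compound 3, that is, nothing beyond the usual scatter, and most likely another limit. Compound 3 is therefore estimated at 60 ug/mL, within 30 ug/mL to 120 ug/mL.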

Compound 3, half-maximal cytotoxic concentration: > 50 ug/mL
Compound 3 ended at the assay's limit; the forecaster's own chance of this, stated with the estimate: 70%; the middle value lies beyond the limit too.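

In this assay, compound 3 gives > 50 ug/mL, which is a limit and not a number. Within the data shown here, as compound 1 also stands at a limit, no step from compound 1 to compound 3 can be read. The compounds shown leave open whether 3,4-dimethoxyphenyl or 4-propoxyphenyl on the carbonyl carbon is better tolerated, and at what concentration either compound reaches half-maximal cytotoxicity.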